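The source may hold more compounds than are shown below. What is called first, only, known or untested is meant among the compounds shown, and "the series" means these compounds.

Of the compounds shown here, three built on a shared core have been tested in a functional assay on the whole organism (Cricetulus griseus) with Cricetinae gen. sp. as the target; a higher number here means that more compound is needed for the effect, a lower number that less compound is needed. Compound 1 `Cc1ccccc1-c1n[nH]c(-c2ccc(F)cc2)n1` gives 3.5 mg/kg. Compound 2 `Cc1ccccc1-c1n[nH]c(-c2ccc(-c3ccccc3)cc2)n1` gives 10 mg/kg. Between them lies one change, (phenyl in place of fluoro on an aromatic carbon), and it made the step of a 2.9-fold higher number from compound 1 to compound 2 (0.46 log units; beyond the scatter). Compound 3 `CCc1ccccc1-c1n[nH]c(-c2cccc(F)c2)n1` gives 0.4 mg/kg, the lowest number of the three; how the core of compound 3 differs from the core of compound 1 is not broken down here.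

Compound 4 `CCc1ccccc1-c1n[nH]c(-c2cccc(-c3ccccc3)c2)n1` has not yet been measured in this assay. It differs from compound 3 by phenyl in place of fluoro on an aromatic carbon. For the measured compounds named here, this is the same kind of change as the one between compound 1 and compound 2, but not the same: in compound 4 the phenyl sits meta to a large group, whereas in compound 2 it sits para to a large group. A step of similar size is expected, namely a 3.0-fold higher number from compound 3 to compound 4 (0.48 log units; beyond the scatter), because the like change earlier gave a 2.9-fold higher number from compound 1 to compound 2 (0.46 log units; beyond the scatter), with extra room left for the different place. Compound 4 is therefore expected to give about 1.2 mg/kg in this assay, most likely between 0.5 mg/kg and 3.5 mg/kg.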

Compound 4, dose for half-maximal effect: 10 mg/kg
Compound 4: middle estimate off by 8.3-fold (0.92 log units), on the low side; measured number above the stated range.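

In this assay, putting phenyl in place of fluoro gave a 25-fold higher number from compound 3 to compound 4 (1.40 log units; beyond the scatter) and so moved the number in the same direction as the earlier step, but much further. The direction held on both cores, whereas the size did not carry over from one core to the other: the same change on two cores in this assay, a 2.9-fold higher number (0.46 log units; beyond the scatter) from compound 1 to compound 2 and a 25-fold higher number (1.40 log units; beyond the scatter) from compound 3 to compound 4, 8.8-fold (0.94 log units) apart, beyond the scatter of two such steps. This does not show which feature of the cores sets the size of the step, since compound 1 and compound 3 differ in more than one place and the phenyl does not stand in the same place in compound 2 and compound 4, and two pairs make no rule for other cores in the series.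

The compounds shown leave open how the number would respond to a group other than phenyl or fluoro on that aromatic carbon, such as chloro, methoxy, an amine or a carboxylic acid. They also leave open whether the large step comes from the place meta to a large group or from the rest of the core, which a pair with only one of these changed could separate.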